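A few compounds are considered here, and "the series" means these few. Any claim that something is new, unique, unknown or untested is made for them only; others in the source may bear on it.

Of the compounds shown here, three have been measured in a functional assay on the whole organism for inhibition, with Rattus norvegicus as the target, at a dose of 30 mg/kg; on this read-out lower numbers stand for less inhibition and higher numbers for more inhibition at the one dose given (going by the name of the read-out). Compound 1 `Nc1ncnn1/C(S)=N/C1CCCCC1` gives 31% and compound 2 `C/N=C(\S)c1cccnc1N` gives 27%. Compound 3 `C/N=C(\S)n1nc(-c2ccc(C#N)cc2)nc1N` gives 87%, the highest of the three; compound 1 is its nearest neighbour yet lies well below it, beyond the scatter, and compound 2 lies further below still. Compound 4 `C/N=C(\S)n1nc(-c2ccc(C(F)(F)F)cc2)nc1N` differs from compound 3 in one place: trifluoromethyl in place of cyano on an aromatic carbon. Among the compounds with values here, no step between two measured compounds shows how such a swap behaves, so the expectation rests on compound 3 alone. Compound 4 is expected to sit a little lower, a step of a number 12 percentage points lower from compound 3 to compound 4 (beyond the scatter) in this assay, within or near the scatter. The estimate for compound 4 in this assay is 75%, between 55% and 92%.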

Compound 4, a percentage reported as inhibition, in the whole organism at one dose (the size of the read-out at that dose, not a potency): 91%
Estimate against measurement, compound 4: 16 percentage points below; the measured number falls inside the stated range.
By their numbers in this assay, from the lowest: compounds 2 and 1 (each within the scatter of the next); then compounds 3 and 4 (each within the scatter of the next).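

In this assay, trifluoromethyl in place of cyano on the aromatic carbon para to a large group gives a number 4 percentage points higher from compound 3 to compound 4 (within the scatter). The high number of compound 3 therefore does not depend on the nitrile at this position, since a group with no hydrogen-bond acceptor serves equally well at this one dose. Nothing measured here explains why the two groups read alike.

On these data alone, whether an amine, a methoxy group or a carboxylic acid at the same place would keep the number high remains open. So does whether compound 3 and compound 4 would separate at another dose.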